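Swapping ethyl for furan-2-yl on compound 1

The source may report more compounds than this note shows. Statements on the series, on what has been measured and on what is new or still open speak of the compounds shown alone.

Among the compounds with values here, in a functional assay on MV4-11 cells (Homo sapiens) for cytotoxicity, read by MTT assay, with a stated time of 72 h (on this read-out higher numbers stand for weaker inhibition and lower numbers for stronger inhibition), compound 1 (`CCOC(=O)c1csc2nc(-c3ccc(NC(=O)CC)cc3)cn12`) gives 9520 nM, the only exact number so far. Compound 2 (`CCCS(=O)(=O)Nc1ccc(-c2cn3c(C(=O)OCC)csc3n2)cc1`) reads > 20000 nM, and this is a limit, not a number. Within the data shown here, the single measured step, an at least 2.1-fold higher number from compound 1 to compound 2 (0.32 log units; beyond the scatter), puts propylsulfonyl in place of propanoyl on a nitrogen on an aromatic ring, and its full size stays unknown given (the limit of > 20000 nM in this assay, at which 1 of the 2 values shown sits). Compound 3 (`CCOC(=O)c1csc2nc(-c3ccc(NC(=O)c4ccco4)cc3)cn12`) keeps the carbonyl that this step removed and changes what sits on it: furan-2-yl in place of ethyl on a carbonyl carbon. The measured step therefore bears only loosely on this change, and it gives no direction for it. No clear shift beyond the usual scatter is expected in this assay, and the estimated step is a 1.2-fold lower number from compound 1 to compound 3 (0.08 log units; within the scatter). For compound 3 the expected value is 8000 nM, with an estimated range of 2500 nM to 20000 nM.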

Compound 3, half-maximal inhibitory concentration: 9920 nM
Compound 3: the middle estimate sits 1.2-fold (0.09 log units) below what was measured, and the stated range covers the measured number.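

In this assay, furan-2-yl on the carbonyl carbon reads the same as ethyl, with a 1.0-fold higher number from compound 1 to compound 3 (0.02 log units; within the scatter), so the larger group with its five-membered aromatic ring brings no shift beyond the scatter. The earlier step replaced the carbonyl itself, whereas this pair shows that, at least for these two groups, what sits on a retained carbonyl can change while the number holds. Putting (furan-2-yl)carbonyl in place of propylsulfonyl gives an at least 2.0-fold lower number from compound 2 to compound 3 (0.30 log units; that floor lies within the scatter), which is only a floor, as the reading of compound 2 is a limit and not a number: the limit of > 20000 nM in this assay, at which 1 of the 3 values shown sits.

The compounds shown leave open whether a longer chain, or a group carrying an amine or a carboxylic acid, on this carbonyl carbon would move the number beyond the scatter. They also do not tell whether phenyl, a six-membered ring, would read like furan-2-yl.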